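Methoxy for Chloro on the Benzyl Ring of Compound 3

The compounds below may be only part of what the source reports. "The series", "measured", "known", "first", "only" and "open" are said of these compounds alone.

The three measured compounds share one core and differ only in the halogen-bearing benzyl group on the amine. Compound 1 `O=S(=O)(NCCCNCc1ccccc1Cl)c1cc(C(F)(F)F)cc(C(F)(F)F)c1` gives 11000 nM in a functional assay on MIA PaCa-2 cells (Homo sapiens) for inhibition, read by MTT assay, with a stated time of 72 h; on this read-out higher numbers stand for weaker inhibition of growth and lower numbers for stronger inhibition of growth. Compound 2 `O=S(=O)(NCCCNCc1ccc(Br)cc1)c1cc(C(F)(F)F)cc(C(F)(F)F)c1` gives 2300 nM in this assay, and compound 3 `O=S(=O)(NCCCNCc1cccc(Cl)c1)c1cc(C(F)(F)F)cc(C(F)(F)F)c1` gives 4400 nM. Compound 3 thus holds the second highest of the three numbers: the step of a 2.5-fold lower number from compound 1 to compound 3 (0.40 log units; beyond the scatter) lies beyond the scatter, whereas the step of a 1.9-fold higher number from compound 2 to compound 3 (0.28 log units; within the scatter) lies within it. The step of a 4.8-fold lower number from compound 1 to compound 2 (0.68 log units; beyond the scatter) is the largest of the three.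

Compound 4 `COc1cccc(CNCCCNS(=O)(=O)c2cc(C(F)(F)F)cc(C(F)(F)F)c2)c1` differs from compound 3 by methoxy in place of chloro on an aromatic carbon. Within the data shown here, none of the measured steps exchanges chloro for methoxy; all three move a halogen around the ring, and they were modest at most. Among the measured compounds shown here, with no direct precedent, compound 4 is expected to sit close to compound 3, the estimated step of a 1.1-fold higher number from compound 3 to compound 4 (0.06 log units; within the scatter) being not beyond the scatter. The estimate for compound 4 in this assay is therefore 5000 nM, with a range from 2000 nM to 12000 nM.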

Compound 4, concentration for 50% growth inhibition: 3400 nM
Beside the measured number, compound 4's estimate is 1.5-fold (0.17 log units) above it; the range from low to high includes it.
By their numbers in this assay, from the lowest: compounds 2, 4 and 3 (each within the scatter of the next); then compound 1.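

In this assay, among these compounds, the first non-halogen group at this place, on an aromatic carbon meta to a large group, changes the number only within the scatter (a 1.3-fold lower number from compound 3 to compound 4 (0.11 log units; within the scatter)), so here chloro can give way to methoxy, which adds a hydrogen-bond acceptor, with no readable loss or gain. Compound 4 also stays within the scatter of the 4-bromophenyl compound (a 1.5-fold higher number from compound 2 to compound 4 (0.17 log units; within the scatter)), while the 2-chlorophenyl compound remains apart, as the weakest of the four (a 3.2-fold lower number from compound 1 to compound 4 (0.51 log units; beyond the scatter)). Nothing at hand bears on why this exchange is so quiet.

The compounds shown leave open whether a hydroxyl, a nitrile or a carboxylic acid on this same aromatic carbon would also stay within the scatter of compound 3. They also leave open whether methoxy would behave alike on a longer chain.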